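A few compounds are considered here, and "the series" means these few. Any claim that something is new, unique, unknown or untested is made for them only; others in the source may bear on it.

The measured compounds:
In an ADME assay on MDBK cells (Bos taurus) for cytotoxicity, read by MTT assay, with a stated time of 96 h (a lower number here means that less compound is tolerated, a higher number that more compound is tolerated), compound 1 `FC(F)(F)c1cccc(NC(=S)Nc2ccc(I)cc2)c1` gives 9500 nM.
In this assay compound 2 `O=[N+]([O-])c1ccc(NC(=S)Nc2cccc(C(F)(F)F)c2)cc1` gives 10000 nM.
In this assay compound 3 `FC(F)(F)c1cccc(NC(=S)Nc2ccccc2)c1` gives 49000 nM.

Compound 3 stands highest of the three numbers in this assay: its nearest neighbour is compound 2, with a 4.9-fold higher number from compound 2 to compound 3 (0.69 log units; beyond the scatter), and the furthest is compound 1, with a 5.2-fold higher number from compound 1 to compound 3 (0.71 log units; beyond the scatter). Both of those steps strip a substituent from the ring of the shared core, and both lie beyond the scatter in the same direction. Compound 1 and compound 2 themselves sit within the scatter of each other, as a 1.1-fold higher number from compound 1 to compound 2 (0.02 log units; within the scatter) shows.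

Compound 4 `CCOC(=O)c1ccc(NC(=S)Nc2cccc(C(F)(F)F)c2)cc1` is reached from compound 3 by one change: ethoxycarbonyl in place of hydrogen on an aromatic carbon. Going by the values given here, the steps that bear on it are the two just named, which run the other way, from a substituted aromatic carbon to hydrogen; read in reverse, each is a modest downward step. Because compound 1 gives 9500 nM and compound 2 gives 10000 nM, two different groups at this carbon have given numbers close to one another. The step to compound 4 is therefore expected to be a modest one downward, a 4.1-fold lower number from compound 3 to compound 4 (0.61 log units; beyond the scatter). Compound 4 is estimated at 12000 nM in this assay, with a range from 4000 nM to 40000 nM.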

Compound 4, half-maximal cytotoxic concentration: 64000 nM
Compound 4: the middle estimate sits 5.3-fold (0.73 log units) below what was measured, and the stated range ends below it.
By their numbers in this assay, from the lowest: compounds 1 and 2 (each within the scatter of the next); then compounds 3 and 4 (each within the scatter of the next).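

In this assay, ethoxycarbonyl on this aromatic carbon, para to a large group, gives a result that stays within the scatter of the unsubstituted compound, as a 1.3-fold higher number from compound 3 to compound 4 (0.12 log units; within the scatter) shows. The same carbon therefore carries one group that leaves the number in place, whereas iodo and nitro both sit clearly apart from it: exchanging those groups for ethoxycarbonyl gives a 6.4-fold higher number from compound 2 to compound 4 (0.81 log units; beyond the scatter) and a 6.7-fold higher number from compound 1 to compound 4 (0.83 log units; beyond the scatter), so the earlier drop belongs to compounds 1 and 2 and does not follow from filling this carbon with just any group. Nothing available here accounts for why ethoxycarbonyl parts from iodo and nitro in this way.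

With only three groups at this carbon, the compounds shown leave open whether a carboxylic acid, an amine or a longer ester chain would fall with compounds 3 and 4 or with compounds 1 and 2. They also leave open whether ethoxycarbonyl would behave the same way if the trifluoromethyl group on the other ring were replaced by a chlorine atom or a methoxy group.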